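Methyl on the aryl ring of compound 2

A few compounds are considered here, and "the series" means these few. Any claim that something is new, unique, unknown or untested is made for them only; others in the source may bear on it.

In a functional assay on HeLa cells (Homo sapiens) for antiproliferative activity, read by sulforhodamine B assay, with a stated time of 48 h (a lower number here means a stronger inhibitor of growth, a higher number a weaker inhibitor of growth), compound 1 `S=c1[nH]nc(C2=C(Cl)c3ccccc3CCC2)o1` gives 981 nM. Compound 2 `Cc1cc2c(cc1C)C(Cl)=C(c1nnc(-c3ccccc3)o1)CCC2` gives 4680 nM, the higher of the two numbers, and its gap to compound 1 lies beyond the scatter. These two compounds differ in more than one place, so they offer no single-change step to reason from.

The next compound is compound 3 `Cc1ccc(-c2nnc(C3=C(Cl)c4cc(C)c(C)cc4CCC3)o2)cc1`. The change from compound 2 is methyl in place of hydrogen on an aromatic carbon, which turns phenyl into 4-methylphenyl. For the measured compounds named here, the series holds no measured example of this change, so a large step has no support and no direction is favoured. In this assay the expected result is a 1.2-fold lower number from compound 2 to compound 3 (0.07 log units; within the scatter), an estimated step that stays within the scatter. For compound 3 the estimated value is 4000 nM, with an expected range of 1500 nM to 11000 nM.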

Compound 3, concentration for 50% growth inhibition: 679 nM
The estimate for compound 3 lay 5.9-fold (0.77 log units) above the measured number, and the stated range ends above it.
By their numbers in this assay, from the lowest: compounds 3 and 1 (each within the scatter of the next); then compound 2.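

In this assay, for the compounds shown here, the change from phenyl to 4-methylphenyl gives a 6.9-fold lower number from compound 2 to compound 3 (0.84 log units; beyond the scatter) and provides the first single-change step. The position para to a large group therefore responds to substitution, and methyl in place of hydrogen here gives a stronger inhibitor of growth, although this rests on a single pair. No measured information accounts for the size of this step.

From the compounds shown here alone, whether the step is specific to methyl remains open: a chlorine, a methoxy, an amine or a carboxylic acid on the same carbon would test that. Also open, going by these compounds, is whether the same change would give a similar step on a core without the two ring methyl groups shared by compound 2 and compound 3.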